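The compounds below may be only part of what the source reports. "The series", "measured", "known", "first", "only" and "open" are said of these compounds alone.

Compound 1 `CC(C)=CC[C@@H](OC[C@H](C)O)C1=CC(=O)c2c(O)ccc(O)c2C1=O`: 24500 nM
Compound 2 `CCCC(CC(=O)O[C@H](CC=C(C)C)C1=CC(=O)c2c(O)ccc(O)c2C1=O)OC(C)=O`: 55700 nM

Both compounds were tested in a functional assay on DU-145 cells (Homo sapiens) for cytotoxicity, read by MTT assay; on this read-out lower numbers stand for stronger inhibition and higher numbers for weaker inhibition. Compound 1 gives 24500 nM, while compound 2 gives 55700 nM, the higher of the two numbers; the gap between them lies beyond the usual scatter of repeated measurements, so compound 2 is the weaker of the pair.

Compound 3 `CC(C)=CC[C@@H](OC(=O)C1CCCCO1)C1=CC(=O)c2c(O)ccc(O)c2C1=O` keeps the shared core and the ester link of compound 2 but changes what sits on the carbonyl carbon: oxan-2-yl in place of 2-acetoxypentyl on a carbonyl carbon. Among the compounds with values here, no step between measured compounds covers a change of this kind, so the expectation rests only on the two values shown. Because compound 2 sits at 55700 nM and the ester is retained, the step expected from compound 2 to compound 3 is a 1.4-fold lower number from compound 2 to compound 3 (0.14 log units; within the scatter), a small move that may not exceed the scatter. Compound 3 is estimated at 40000 nM, with a range from 15000 nM to 110000 nM.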

Compound 3, half-maximal inhibitory concentration: 24700 nM
Compound 3: middle estimate off by 1.6-fold (0.21 log units), on the high side; low and high end bracket the measured number.
By their numbers in this assay, from the lowest: compounds 1 and 3 (each within the scatter of the next); then compound 2.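

In this assay, oxan-2-yl in place of 2-acetoxypentyl on the carbonyl carbon gives a 2.3-fold lower number from compound 2 to compound 3 (0.35 log units; beyond the scatter) and so shows that the number responds to what the ester carries at this place. The second step, a 1.0-fold higher number from compound 1 to compound 3 (0.00 log units; within the scatter), shows that (oxan-2-yl)carbonyl and 2-hydroxypropyl on this oxygen cannot be told apart in this assay, even though one brings a ring and a carbonyl and the other does neither. Nothing available explains why the ester step occurs.

This single swap removes the open chain and its acetoxy group and adds a ring all at once, so it stays open which of these changes accounts for the step. Also open, going by these compounds, is how a plain pentyl chain, a cyclohexyl ring or an amine-bearing group would read out on the same carbonyl carbon.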